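One Swap Already Measured, Expected to Repeat

A few compounds are considered here, and "the series" means these few. Any claim that something is new, unique, unknown or untested is made for them only; others in the source may bear on it.

Of the compounds shown here, three have been measured in a physicochemical assay for acid dissociation, and a fourth is waiting. Compound 1 `O=[N+]([O-])c1cccc(NS(=O)(=O)c2ccc(Br)cc2)c1` gives 7.42 in this assay. Compound 3 `O=[N+]([O-])c1ccc(S(=O)(=O)Nc2cccc([N+](=O)[O-])c2)cc1` differs from compound 1 by a single change, (nitro in place of bromo on an aromatic carbon), and compound 3 gives 5.51. That change made the step of a number 1.91 log units lower from compound 1 to compound 3 (beyond the scatter). Compound 2 `O=S(=O)(Nc1ccc(Cl)cc1)c1ccc(Br)cc1` gives 8.24, the highest of the three numbers; how its core differs from the core of compound 1 is not broken down here, the two simply differ in more than one place.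

The unmeasured compound 4 `O=[N+]([O-])c1ccc(S(=O)(=O)Nc2ccc(Cl)cc2)cc1` stands to compound 2 as compound 3 stands to compound 1: it carries nitro in place of bromo on an aromatic carbon. Since the leaving group, the entering group and the place are described in the same words for both pairs, this is the same change, seen for a second time among the four compounds.

The expectation for compound 4 rests on that one earlier step, because the change from compound 1 to compound 3 gave a number 1.91 log units lower from compound 1 to compound 3 (beyond the scatter). Carrying a step of about that size over from compound 2, compound 4 is expected to show a number 1.94 log units lower from compound 2 to compound 4 (beyond the scatter) in this assay. Compound 4 is therefore estimated at 6.3, most likely between 5.8 and 6.8, with a single prior example being the only basis.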

Compound 4, acid dissociation constant: 6.24
The estimate for compound 4 lay 0.06 log units above the measured number; the measured number falls inside the stated range.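

In this assay, putting nitro in place of bromo on an aromatic carbon gives a number 2.00 log units lower from compound 2 to compound 4 (beyond the scatter) and so repeats on a second core what was already seen as a number 1.91 log units lower from compound 1 to compound 3 (beyond the scatter), with both steps large and pointing the same way. This shows that, in these two matched pairs, the change kept its direction and its broad size when it moved from one core to the other, which is what a medicinal chemist hopes for when using a step seen on one compound to estimate a number for another. It does not show that the step would hold on every core in the series, since two pairs are a small base, and nothing available here explains why the number falls with this change.

Going by these compounds, both pairs share the same leaving group and the same entering group, so it remains open whether a nitrile, an amine or a carboxylic acid in place of bromo would shift the number in a similar way. On these data alone, it also remains open whether nitro in place of bromo would repeat this step on a core carrying methoxy in place of the chloro of compound 4.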